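Reversing an Amide on a Shared Five-Membered Core

A few compounds are considered here, and "the series" means these few. Any claim that something is new, unique, unknown or untested is made for them only; others in the source may bear on it.

Three compounds have numbers in an assay on CHO-K1 cells for displacement of a labelled ligand from prostaglandin E2 receptor EP1 subtype (Homo sapiens); on this read-out lower numbers stand for stronger inhibition and higher numbers for weaker inhibition. Compound 1 `Cc1cc(C(=O)O)nn1C(C)c1cc(Cl)ccc1OCc1ccccc1` gives 10 nM in this assay, compound 2 `Cc1cc(C(=O)NCc2ccccc2)nn1Cc1cc(Cl)ccc1OCc1ccccc1` gives 39.8 nM, and compound 3 `Cc1cc(C(=O)NN2CCOCC2)nn1Cc1cc(Cl)ccc1OCC(C)C` gives 251 nM. Compound 2 thus stands second highest of the three: its nearest neighbour is compound 1, whose number is lower by an amount beyond the scatter, and the furthest is compound 3, whose number is higher by an amount beyond the scatter. No two of these compounds differ in only one place, so no single step between measured compounds can be read off.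

Compound 4 `Cc1cc(NC(=O)c2c(F)cccc2F)nn1Cc1cc(Cl)ccc1OCc1ccccc1` has not yet been measured. It differs from compound 2 in one place: ((2,6-difluorophenyl)carbonyl)amino in place of benzylcarbamoyl on an aromatic carbon. The group that leaves and the group that enters are close in size, each with 1 hydrogen-bond donor and 1 hydrogen-bond acceptor, and the exchange sits on an aromatic carbon of the five-membered aromatic ring with 2 nitrogen, next to the ring nitrogen.

Among the compounds with values here, nothing among the measured compounds shows what such an exchange does. The expected step in this assay is none beyond the scatter: a 1.3-fold higher number from compound 2 to compound 4 (0.10 log units; within the scatter). Compound 4 is estimated to give about 50 nM in this assay, within a range from 10 nM to 300 nM.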

Compound 4, half-maximal inhibitory concentration: 12.6 nM
Beside the measured number, compound 4's estimate is 4.0-fold (0.60 log units) above it; low and high end bracket the measured number.
By their numbers in this assay, from the lowest: compounds 1 and 4 (each within the scatter of the next); then compound 2; then compound 3.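

The exchange of benzylcarbamoyl for ((2,6-difluorophenyl)carbonyl)amino on an aromatic carbon of the shared core gives, in this assay, a 3.2-fold lower number from compound 2 to compound 4 (0.50 log units; beyond the scatter), the only step among these compounds that can be read at a single place. It shows that this position does not demand the benzylcarbamoyl group: turning the amide around, so that its nitrogen rather than its carbonyl is attached to the ring, goes with stronger inhibition, while both groups keep one six-membered aromatic ring, one hydrogen-bond donor and one hydrogen-bond acceptor. No measurement here accounts for the size or the direction of this step.

The exchange alters several things at once, since the amide is reversed, the methylene linker is lost and fluorine enters, and the compounds shown do not separate these changes from one another. As far as these compounds go, whether a plain benzoylamino group, with hydrogen in place of both fluorines, or a phenylacetylamino group, which would restore the methylene in the reversed amide, would give a step of similar size remains open.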